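The compounds below may be only part of what the source reports. "The series", "measured", "known", "first", "only" and "open" are said of these compounds alone.

Compound 1 `COc1cc(/C=C2\CN(S(=O)(=O)c3ccc(F)cc3)C/C(=C\c3cccc([N+](=O)[O-])c3)C2=O)cc(OC)c1OC` and compound 2 `COc1cc(/C=C2\CN(S(=O)(=O)c3ccc(F)cc3)C/C(=C\c3ccc(C#N)cc3)C2=O)cc(OC)c1OC` are built on one core, while compound 3 `CC(=O)Nc1ccc(S(=O)(=O)N2C/C(=C\c3cccc([N+](=O)[O-])c3)C(=O)/C(=C/c3ccccc3F)C2)cc1` and compound 4 `CC(=O)Nc1ccc(S(=O)(=O)N2C/C(=C\c3ccc(C#N)cc3)C(=O)/C(=C/c3ccccc3F)C2)cc1` are built on another. In a functional assay on SMMC-7721 cells (Homo sapiens) for cytotoxicity, read by MTT assay, with a stated time of 24 h (a higher number here means a weaker inhibitor, a lower number a stronger inhibitor), compound 1 gives 4900 nM, compound 2 gives 4120 nM, and compound 3 gives 10200 nM, the highest of the three measured numbers. The change from compound 1 to compound 2 is 4-cyanophenyl in place of 3-nitrophenyl on a double-bonded chain carbon bound to a double-bonded ring carbon, and it made a 1.2-fold lower number from compound 1 to compound 2 (0.08 log units; within the scatter). The same change, (4-cyanophenyl in place of 3-nitrophenyl on a double-bonded chain carbon bound to a double-bonded ring carbon), turns compound 3 into compound 4; the difference between the two cores is not broken down here. Because the earlier step of a 1.2-fold lower number from compound 1 to compound 2 (0.08 log units; within the scatter) stayed within the scatter, the step of a 1.2-fold lower number from compound 3 to compound 4 (0.08 log units; within the scatter) is expected to be about as small. Compound 4 is therefore estimated at 8500 nM, most likely falling between 4500 nM and 16000 nM.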

Compound 4, half-maximal inhibitory concentration: 3150 nM
Compound 4: middle estimate off by 2.7-fold (0.43 log units), on the high side; measured number below the stated range.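

In this assay, putting 4-cyanophenyl in place of 3-nitrophenyl gave a 3.2-fold lower number from compound 3 to compound 4 (0.51 log units; beyond the scatter). The size of this step therefore did not carry over from one core to the other, so a step measured on one core was a poor guide to the step on the second: the same change on two cores in this assay, a 1.2-fold lower number (0.08 log units; within the scatter) from compound 1 to compound 2 and a 3.2-fold lower number (0.51 log units; beyond the scatter) from compound 3 to compound 4, 2.7-fold (0.43 log units) apart, beyond the scatter of two such steps This is a single comparison between two cores that differ in more than one place, so it does not show which difference matters or what would happen on a third core.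

Still open, on these data alone, is how a phenyl ring carrying an amine or a carboxylic acid would behave at the same place on each core. As far as these compounds go, whether such groups would also give steps of different size on the two cores remains unknown.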